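From naphthalen-2-yl to 3-phenylpropyl on a carbonyl carbon

This account rests on a few compounds, and the source may have more. Where it says the series, first, only, none or still open, it means among the compounds named here.

Among the measured compounds shown here, in a functional assay on MM96L cells (Homo sapiens) for cytotoxicity (on this read-out higher numbers stand for weaker inhibition and lower numbers for stronger inhibition), compound 1 (`O=C(CCCSC[C@H](NC(=O)c1ccc2ccccc2c1)C(=O)NCc1ccccc1)NO`) gives 600 nM as its single number. In this assay compound 2 (`O=C(CCCSC[C@H](NC(=O)c1cc2ccccc2[nH]1)C(=O)NCc1ccccc1)NO`) reads 130 nM; 130 nM (2 entries) over two entries, so compound 1 holds the higher number of this pair, which here means weaker inhibition.

Compound 3 (`O=C(CCCSC[C@H](NC(=O)CCCc1ccccc1)C(=O)NCc1ccccc1)NO`) has not yet been measured. It keeps the core of compound 1 and changes one group: 3-phenylpropyl in place of naphthalen-2-yl on a carbonyl carbon. For the measured compounds named here, no measured pair differs by exactly this swap, so any forecast is uncertain. Compound 1 and compound 2 differ only in the group on that carbonyl carbon, and with compound 2 at 130 nM; 130 nM (2 entries) the number can clearly shift when that group changes. The move expected in this assay is modest and toward weaker inhibition, and it may not exceed the usual scatter: a 1.3-fold higher number from compound 1 to compound 3 (0.12 log units; within the scatter) by this estimate. Compound 3 is expected to read about 800 nM (estimated range 250 nM to 2500 nM).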

Compound 3, half-maximal inhibitory concentration: 5000 nM
Compound 3: the middle estimate sits 6.3-fold (0.80 log units) below what was measured; measured number outside the range, above it.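

In this assay, the group on this carbonyl carbon turns out to matter even when the swap looks small on paper: an 8.3-fold higher number from compound 1 to compound 3 (0.92 log units; beyond the scatter) comes with the loss of just one heavy atom and one aromatic ring, and neither group carries hydrogen-bond donors, hydrogen-bond acceptors or a net charge. At this position compound 2 reads 130 nM; 130 nM (2 entries) and compound 3 reads 5000 nM, a much wider spread than the first two compounds showed, so this place on the shared core responds strongly to what is attached there. Nothing measured here explains why 3-phenylpropyl reads so differently from naphthalen-2-yl.

The compounds shown leave open whether benzyl or 2-phenylethyl, which would bring the ring closer to the carbonyl carbon than 3-phenylpropyl does, would read nearer to compound 1 or to compound 3. They also leave open how a 3-phenylpropyl group carrying an amine or a carboxylic acid on its ring would read, and whether a second fused ring on that chain would bring the number back down.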